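This account rests on a few compounds, and the source may have more. Where it says the series, first, only, none or still open, it means among the compounds named here.

Within the data shown here, compound 2 `NC(=O)c1cc(Cl)c2c(Cl)c(C#CCO)n([C@H]3CCCNC3)c2n1` is one of two compounds measured in a functional assay on KG-1 cells (Homo sapiens) for antiproliferative activity; on this read-out higher numbers stand for an effect only at larger amounts of compound and lower numbers for an effect already at smaller amounts; there compound 2 gives 301 nM. Its number is the highest of the two, and its closest neighbour is compound 1 `CC(C)(C#N)CC#Cc1c(Cl)c2c(Cl)cc(C(N)=O)nc2n1[C@H]1CCCNC1`, which in this assay gives 113 nM. Among the measured compounds shown here, the single step connecting them, a 2.7-fold higher number from compound 1 to compound 2 (0.43 log units; beyond the scatter), replaced a 1-cyano-1-methylethyl group with hydroxy on the saturated chain carbon bound to the triple-bonded carbon.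

Compound 3 `CN1CC(C#Cc2c(Cl)c3c(Cl)cc(C(N)=O)nc3n2[C@H]2CCCNC2)CC1=O` is built from compound 2 by a change at the end of the triple bond: 1-methyl-5-oxopyrrolidin-3-yl in place of hydroxymethyl on a triple-bonded carbon. For the measured compounds named here, the only measured step bears on this change indirectly: shrinking the end of the chain in compound 2 raised the number, so enlarging it again in compound 3, which carries a ring with an acceptor and no donor, is expected to move the number back towards that of compound 1 rather than further away from it. The step from compound 2 to compound 3 is therefore estimated to be a 2.0-fold lower number from compound 2 to compound 3 (0.30 log units; within the scatter). For compound 3 the expected value is 150 nM, with a range from 60 nM to 400 nM.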

Compound 3, half-maximal effective concentration: 155 nM
For compound 3 the middle estimate is 1.0-fold (0.01 log units) below the measured one, and the stated range covers the measured number.
By their numbers in this assay, from the lowest: compounds 1, 3 and 2 (each within the scatter of the next, the first and the last beyond it).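

Compound 3 shows that a much larger group with a ring can sit on this triple-bonded carbon without a clear shift in the number. In this assay the change from hydroxymethyl to 1-methyl-5-oxopyrrolidin-3-yl gives a 1.9-fold lower number from compound 2 to compound 3 (0.29 log units; within the scatter) and so swaps a small open group with a hydrogen-bond donor for a five-membered non-aromatic ring with none. The comparison with the open chain gives a 1.4-fold higher number from compound 1 to compound 3 (0.14 log units; within the scatter) and so cannot separate the ring from 2-cyano-2-methylpropyl, which leaves compound 3 within the scatter of both neighbours even though the gap between those two lies beyond it, and nothing measured here explains these numbers.

Still open, from the compounds shown here alone, is how a group with a basic nitrogen or a charge, such as aminomethyl or a carboxylic acid, would read on this triple-bonded carbon. The compounds shown also leave unsettled whether the methyl on the ring nitrogen of 1-methyl-5-oxopyrrolidin-3-yl or the ring carbonyl matters at all, since a 5-oxopyrrolidin-3-yl group without that methyl would be needed to tell.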